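Trading two chlorines for one fluorine in an inactive pair

The source may report more compounds than this note shows. Statements on the series, on what has been measured and on what is new or still open speak of the compounds shown alone.

The measured compounds and their values:
compound 1, `O=C(Nc1ccccc1O)c1cccc(N2C(=O)c3ccccc3C2=O)c1`, in an in vitro functional assay on HEK293-A cells for antagonist activity at metabotropic glutamate receptor 5 (Rattus norvegicus), read by calcium flux (a higher number here means a weaker inhibitor, a lower number a stronger inhibitor), gives 77 nM
compound 2, `COc1ccccc1C(=O)Nc1cccc(NC(=O)c2ccc(Cl)cc2)c1`, in this assay gives > 30000 nM, a limit of the assay and not a number
compound 3, `COc1ccccc1C(=O)Nc1cccc(NC(=O)c2ccc(Cl)c(Cl)c2)c1`, in this assay gives > 30000 nM, again a limit of the assay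

Compound 3 stands at the limit of the assay, and compound 2 stands at the same limit (the limit of > 30000 nM in this assay, at which 2 of the 3 values shown sit). The step from compound 2 to compound 3 is therefore a step that the two limits leave unreadable from compound 2 to compound 3, and it gives no usable direction.

Compound 4, `COc1ccccc1C(=O)Nc1cccc(NC(=O)c2ccc(F)cc2)c1`, differs from compound 3 by 4-fluorophenyl in place of 3,4-dichlorophenyl on a carbonyl carbon. Among the measured compounds shown here, the only measured step that touches this part of the structure is the one from compound 2 to compound 3, and that step is unreadable, so nothing measured tells how the change to compound 4 should move the value. Since both compound 2 and compound 3 sit at the limit, compound 4 is expected to sit there as well, so the step from compound 3 to compound 4 is estimated as a number no higher from compound 3 to compound 4 (the limit leaves the size open). For compound 4 the expected value is 30000 nM, with a range from 10000 nM to 100000 nM.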

Compound 4, half-maximal inhibitory concentration: > 30000 nM
Compound 4: only a limit was reported; the forecaster's own chance of this, stated with the estimate: 80%; the middle value sits exactly at the limit.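

In this assay compound 4 gives > 30000 nM, a limit of the assay and not a number. Among the compounds shown here, its steps from compound 2 and compound 3 therefore cannot be read, and no new step emerges: the limit of > 30000 nM in this assay, at which 3 of the 4 values shown sit. The compounds shown leave open whether fluoro or chloro on this aromatic ring changes the inhibition at all.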